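Swapping bromo for acetamido in a cytotoxicity series

A few compounds are considered here, and "the series" means these few. Any claim that something is new, unique, unknown or untested is made for them only; others in the source may bear on it.

Compound 1 `CC(=O)Nc1ccc(S(=O)(=O)N2C/C(=C\c3cccnc3)C(=O)/C(=C/c3ccccc3F)C2)cc1`: 4560 nM
Compound 2 `O=C1/C(=C/c2cccnc2)CN(S(=O)(=O)c2ccc(Br)cc2)C/C1=C\c1ccccc1C(F)(F)F`: 2730 nM

In a functional assay on HepG2 cells (Homo sapiens) for cytotoxicity, read by MTT assay, with a stated time of 24 h (on this read-out lower numbers stand for stronger inhibition and higher numbers for weaker inhibition), compound 1 gives 4560 nM and compound 2 gives 2730 nM. These two values lie within the usual scatter of each other, so repeat measurements could differ by as much, and compound 2 cannot be ranked against compound 1.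

Compound 3 `CC(=O)Nc1ccc(S(=O)(=O)N2C/C(=C\c3cccnc3)C(=O)/C(=C/c3ccccc3C(F)(F)F)C2)cc1` differs from compound 2 in one place: it has acetamido in place of bromo on an aromatic carbon, para to a large group (acetamido in place of bromo on an aromatic carbon). For the measured compounds named here, no measured pair shows this change alone, so the data give no direct size for it. Only a small shift is expected in this assay, with no change beyond the scatter. The expected step is a 1.3-fold higher number from compound 2 to compound 3 (0.12 log units; within the scatter). For compound 3 the estimated value is 3600 nM, with an expected range of 1600 nM to 7500 nM.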

Compound 3, half-maximal inhibitory concentration: 4330 nM
Compound 3: the middle estimate sits 1.2-fold (0.08 log units) below what was measured; the measured number falls inside the stated range.
By their numbers in this assay, from the lowest: compounds 2, 3 and 1 (each within the scatter of the next).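

In this assay, the swap at this position can now be read directly: acetamido in place of bromo gives a 1.6-fold higher number from compound 2 to compound 3 (0.20 log units; within the scatter) and so cannot be told apart from no change, even though acetamido carries a hydrogen-bond donor and acceptor that bromo lacks. The second changed place can be read as well, since trifluoromethyl in place of fluoro on an aromatic carbon gives a 1.1-fold lower number from compound 1 to compound 3 (0.02 log units; within the scatter) and again leaves the two compounds indistinguishable. No supporting measurement bears on what lies behind these small steps.

With only these groups shown, it stays open whether any substituent at either place can move the number beyond the scatter. A free amine or a carboxylic acid on the aromatic carbon that holds acetamido, or a longer chain there, would test this.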